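Extending the sulfonamide chain: a second amino-to-dimethylamino step

The source may hold more compounds than are shown below. What is called first, only, known or untested is meant among the compounds shown, and "the series" means these compounds.

Measured compounds:
compound 1 `NS(=O)(=O)CCNc1nonc1/C(=N/O)Nc1ccc(F)c(Br)c1` — 11 nM
compound 2 `CN(C)S(=O)(=O)CCNc1nonc1/C(=N/O)Nc1ccc(F)c(Br)c1` — 17 nM
compound 3 `NS(=O)(=O)CCCNc1nonc1/C(=N/O)Nc1ccc(F)c(Br)c1` — 15 nM

All three were tested in an assay on HeLa cells for inhibition of Indoleamine 2,3-dioxygenase 1 (Homo sapiens), read by spectrophotometry, with a stated time of 24 h; a higher number here means that more compound is needed for the effect, a lower number that less compound is needed. Compounds 1 and 2 differ only by dimethylamino in place of amino on a sulfonyl sulfur, and this change gave a 1.5-fold higher number from compound 1 to compound 2 (0.19 log units; within the scatter). The unmeasured compound 4 `CN(C)S(=O)(=O)CCCNc1nonc1/C(=N/O)Nc1ccc(F)c(Br)c1` carries the same change relative to compound 3: dimethylamino in place of amino on a sulfonyl sulfur. The place is identical in both pairs, so this is the same change made on two cores. The two cores differ by sulfamoylmethyl in place of sulfamoyl on a saturated chain carbon, two bonds along the chain from a nitrogen on an aromatic ring, and that difference on its own gave a 1.4-fold higher number from compound 1 to compound 3 (0.13 log units; within the scatter). Compounds 2 and 3, which have neither the same chain nor the same sulfonyl substituent, gave a 1.1-fold lower number from compound 2 to compound 3 (0.05 log units; within the scatter).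

Among the compounds with values here, since the only measured instance of this change stayed within the scatter, the step from compound 3 to compound 4 is expected to be similar, a 1.5-fold higher number from compound 3 to compound 4 (0.17 log units; within the scatter), resting on compound 1 to compound 2 with a 1.5-fold higher number from compound 1 to compound 2 (0.19 log units; within the scatter). For compound 4 in this assay the estimate is therefore 22 nM, with a plausible range of 10 nM to 45 nM.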

Compound 4, half-maximal effective concentration: 20 nM
Compound 4: the middle estimate sits 1.1-fold (0.04 log units) above what was measured, and the stated range covers the measured number.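

Dimethylamino in place of amino on the sulfonyl sulfur gave a 1.3-fold higher number from compound 3 to compound 4 (0.12 log units; within the scatter) in this assay, and this agrees with the earlier instance of the change: the same change on two cores in this assay, a 1.5-fold higher number (0.19 log units; within the scatter) from compound 1 to compound 2 and a 1.3-fold higher number (0.12 log units; within the scatter) from compound 3 to compound 4, 1.2-fold (0.06 log units) apart, within the scatter of two such steps. The other two new steps also stay within the scatter, with (dimethylsulfamoyl)methyl in place of dimethylsulfamoyl giving a 1.2-fold higher number from compound 2 to compound 4 (0.07 log units; within the scatter) and (dimethylsulfamoyl)methyl in place of sulfamoyl giving a 1.8-fold higher number from compound 1 to compound 4 (0.26 log units; within the scatter) on the same chain position. The change therefore carried over between these two cores without a detectable difference, but two cores that differ only in chain length show neither that it would carry over to a more different core nor that it has a real effect of its own, since each step is within the scatter.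

Going by these compounds, it remains open whether a methylamino group or a ring amine such as morpholine on the sulfonyl sulfur would fit the same picture. A longer chain, or a carboxylic acid in place of the sulfonamide, is also left open.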